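The compounds below may be only part of what the source reports. "The series", "measured", "known", "first", "only" and "open" are said of these compounds alone.

Measured so far in a physicochemical assay for lipophilicity (on this read-out lower numbers stand for lower lipophilicity and higher numbers for higher lipophilicity), on this series:

- compound 1 `CCCC(=O)Oc1c(OC)c(OC)c(OC(=O)CCC)c2ccccc12` gives 4.64 on this scale
- compound 2 `CCC(=O)Oc1c(Oc2ccccc2)c(Oc2ccccc2)c(OC(=O)CC)c2ccccc12` gives 5.8 on this scale

Compound 1 stands lowest of the two, and the gap up to compound 2 lies beyond the scatter. Compound 3 `CCCC(=O)Oc1c(OC)c(OC)c(OC(=O)CCC)c2cc(Cl)ccc12` has not yet been measured. It keeps the core of compound 1 and carries a single change, chloro in place of hydrogen on an aromatic carbon. Among the measured compounds shown here, no two measured compounds differ in one place only, so the data offer no direct guide to the size of this step. In this assay a moderate rise beyond the scatter is nonetheless expected, with an estimated step of a number 0.66 log units higher from compound 1 to compound 3 (beyond the scatter) as the working figure. For compound 3 the expected value is 5.3 as a central estimate, with an estimated range from 4.9 to 5.7 around it.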

Compound 3, partition coefficient: 5.5
Estimate against measurement, compound 3: 0.20 log units below; the measured number falls inside the stated range.
By their numbers in this assay, from the lowest: compound 1; then compounds 3 and 2 (each within the scatter of the next).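

In this assay, chloro in place of hydrogen on an aromatic carbon gives a number 0.86 log units higher from compound 1 to compound 3 (beyond the scatter) with only one heavy atom entering, and no ring or net charge. Among the compounds shown here, this is the first change that can be read at a single place, and it shows that this aromatic position, meta to a fused ring and para to a fused ring, does not leave the read-out unchanged. Nothing measured here accounts for the size of the step.

On these data alone, it remains open whether fluoro, an amine or a carboxylic acid at this same position would shift this assay in the same direction. Also open, as far as these compounds go, is whether chloro on another aromatic carbon of the shared core would give a step of similar size.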